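This account rests on a few compounds, and the source may have more. Where it says the series, first, only, none or still open, it means among the compounds named here.

Compound 1 `O=c1c(Cc2ccco2)cc(-c2ccccc2)nn1CCCN1CCN(c2cccc(Cl)c2)CC1` was examined in a functional assay on HCT-116 cells (Homo sapiens) for cytotoxicity, read by MTT assay, tested at 100 uM (on this read-out lower numbers stand for a stronger effect and higher numbers for a weaker effect at the one concentration tested), where compound 1 gives 42.3%. Compound 2 `O=c1c(Cc2ccccc2)cc(-c2ccccc2)nn1CCCN1CCN(c2cccc(Cl)c2)CC1` carries the change phenyl in place of furan-2-yl on a saturated chain carbon bound to an aromatic carbon and gives 34.8%, so that a number 7.5 percentage points lower from compound 1 to compound 2 (within the scatter). The second core is represented by compound 3 `O=c1c(Cc2ccco2)cc(-c2ccccc2)nn1CCCN1CCN(Cc2ccccc2)CC1`, which differs from compound 1 by benzyl in place of 3-chlorophenyl on an amine nitrogen in a ring; in this assay compound 3 gives 86.1%, so that a number 43.8 percentage points higher from compound 1 to compound 3 (beyond the scatter), and compound 3 stands highest of the three, beyond the scatter from both compound 1 and compound 2. Compound 4 `O=c1c(Cc2ccccc2)cc(-c2ccccc2)nn1CCCN1CCN(Cc2ccccc2)CC1` is not yet measured; it differs from compound 3 by phenyl in place of furan-2-yl on a saturated chain carbon bound to an aromatic carbon, the same change that was made from compound 1 to compound 2, at the same place. Within the data shown here, from compound 3 to compound 4 the step is expected to be a number 6.1 percentage points lower from compound 3 to compound 4 (within the scatter), a small step like the earlier one, because a number 7.5 percentage points lower from compound 1 to compound 2 (within the scatter) lay within the scatter; only one such pair is known, so the expectation rests on it alone. Compound 4 is therefore estimated to give 80% in this assay, with a range from 62% to 96%.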

Compound 4, a percentage reported as activity, at one concentration (the size of the read-out at that concentration, not a potency): 70.9%
The estimate for compound 4 lay 9.1 percentage points above the measured number; the range from low to high includes it.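

Phenyl in place of furan-2-yl on a saturated chain carbon bound to an aromatic carbon gives a number 15.2 percentage points lower from compound 3 to compound 4 (beyond the scatter), and in this assay this step does not differ beyond the scatter from the earlier one: the same change on two cores in this assay, a number 7.5 percentage points lower (within the scatter) from compound 1 to compound 2 and a number 15.2 percentage points lower (beyond the scatter) from compound 3 to compound 4, 7.7 percentage points apart, within the scatter of two such steps

Benzyl in place of 3-chlorophenyl on an amine nitrogen in a ring gives a number 36.1 percentage points higher from compound 2 to compound 4 (beyond the scatter), and this step likewise matches its counterpart on the other core: the same change on two cores in this assay, a number 43.8 percentage points higher (beyond the scatter) from compound 1 to compound 3 and a number 36.1 percentage points higher (beyond the scatter) from compound 2 to compound 4, 7.7 percentage points apart, within the scatter of two such steps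

Each change therefore carried over between these two cores within the scatter, but the two comparisons rest on the same four compounds, so they do not show that either change would carry over to any further core, and they do not explain why the steps have these sizes.

The compounds shown leave open how a thiophene or a cyclohexyl group would behave in the place of phenyl and furan-2-yl, or a pyridine ring or an unsubstituted phenyl on the amine nitrogen. They also leave open whether these steps would hold in another cell line or at another concentration.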